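The source may hold more compounds than are shown below. What is called first, only, known or untested is meant among the compounds shown, and "the series" means these compounds.

In a functional assay on PC-3 cells (Homo sapiens) for cytotoxicity, read by WST assay, with a stated time of 72 h; a higher number here means a weaker inhibitor, a lower number a stronger inhibitor:

- compound 1 `O=C1Nc2c(ccc(F)c2F)C1(c1ccc(O)cc1)c1ccc(F)cc1`: 8.6 nM
- compound 2 `CCCCCC1(c2ccc(O)cc2)C(=O)Nc2c1ccc(F)c2F`: 1.1 nM

Compound 2 holds the lower of the two numbers, making it the stronger inhibitor here. Compound 3 `O=C1Nc2c(ccc(F)c2F)C1(Cc1ccccc1)c1ccc(O)cc1` keeps the shared core but has phenyl in place of butyl on a saturated chain carbon bound to a saturated ring carbon. The same difference reads pentyl to benzyl. Within the data shown here, one measured step bears on this: a 7.8-fold lower number from compound 1 to compound 2 (0.89 log units; beyond the scatter), with pentyl replacing 4-fluorophenyl. Benzyl brings back an aromatic ring, so a smaller step towards a higher number is expected in this assay. The expected step is a 2.7-fold higher number from compound 2 to compound 3 (0.44 log units; beyond the scatter). Compound 3 is estimated at 3 nM, with a range of 0.9 nM to 10 nM.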

Compound 3, half-maximal inhibitory concentration: > 1000 nM
Compound 3: no number, only a limit; the forecaster's own chance of this, stated with the estimate: 2%; at least 330-fold (2.52 log units) between middle value and limit.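

Compound 3 sits at a limit of the assay, not at a number: the limit of > 1000 nM in this assay, at which 1 of the 3 values shown sits. Benzyl on the saturated ring carbon gives an at least 900-fold higher number from compound 2 to compound 3 (2.95 log units; beyond the scatter), and compared with the directly attached ring it gives an at least 110-fold higher number from compound 1 to compound 3 (2.06 log units; beyond the scatter). So a ring attached directly, as 4-fluorophenyl, and a plain chain, as pentyl, both keep low numbers in this assay, while a phenyl carried on a chain carbon does not.

The compounds shown leave open whether a longer chain such as octyl keeps the low number of compound 2. They also leave open how a pentyl chain ending in an amine would behave.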